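The compounds below may be only part of what the source reports. "The series", "measured", "known", "first", "only" and "open" are said of these compounds alone.

Compound 3 `CCCNC(=O)c1cc(Oc2ccc(NC(=O)c3cc4cccnc4n(-c4ccccc4)c3=O)cc2)ccn1` gives the smallest number of the three in a functional assay on NCI-H460 cells (Homo sapiens) for antiproliferative activity, read by MTT assay, with a stated time of 72 h (a higher number here means a weaker inhibitor, a lower number a stronger inhibitor), at 110 nM. Compound 1 `CNC(=O)c1cc(Oc2ccc(NC(=O)c3cc4cccnc4n(-c4ccccc4)c3=O)cc2)ccn1` gives 320 nM, and compound 2 `CNC(=O)c1cc(Oc2ccc(NC(=O)c3cc4cccnc4n(-c4ccc(F)cc4)c3=O)cc2)ccn1` gives 210 nM. The step of a 2.9-fold lower number from compound 1 to compound 3 (0.46 log units; beyond the scatter) lies beyond the scatter, whereas compound 2 and compound 3 stand within it of each other. Compound 4 `CCCNC(=O)c1cc(Oc2ccc(NC(=O)c3cc4cccnc4n(-c4ccc(F)cc4)c3=O)cc2)ccn1` differs from compound 3 by fluoro in place of hydrogen on an aromatic carbon, para to a large group. One measured step carries the same change: a 1.5-fold lower number from compound 1 to compound 2 (0.18 log units; within the scatter), which stayed within the scatter. The expected step is therefore a 1.4-fold lower number from compound 3 to compound 4 (0.14 log units; within the scatter), within the scatter and, if anything, toward a lower number. Compound 4 is estimated at 80 nM, with a range from 40 nM to 180 nM.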

Compound 4, half-maximal inhibitory concentration: 120 nM
For compound 4 the middle estimate is 1.5-fold (0.18 log units) below the measured one; low and high end bracket the measured number.
By their numbers in this assay, from the lowest: compounds 3, 4, 2 and 1 (each within the scatter of the next, the first and the last beyond it).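

In this assay, phenyl to 4-fluorophenyl on a second core gives a 1.1-fold higher number from compound 3 to compound 4 (0.04 log units; within the scatter), so this swap now stays within the scatter on both cores shown: the same change on two cores in this assay, a 1.5-fold lower number (0.18 log units; within the scatter) from compound 1 to compound 2 and a 1.1-fold higher number (0.04 log units; within the scatter) from compound 3 to compound 4, 1.7-fold (0.22 log units) apart, within the scatter of two such steps. Ethyl in place of hydrogen on the chain, read with the 4-fluorophenyl in place, gives a 1.8-fold lower number from compound 2 to compound 4 (0.24 log units; within the scatter), and its gap to the earlier step is no real difference: the same change on two cores in this assay, a 2.9-fold lower number (0.46 log units; beyond the scatter) from compound 1 to compound 3 and a 1.8-fold lower number (0.24 log units; within the scatter) from compound 2 to compound 4, 1.7-fold (0.22 log units) apart, within the scatter of two such steps.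

Still open, on these data alone, is whether chloro, methoxy or an amine on this aromatic carbon would move the number beyond the scatter. Also open, as far as these compounds go, is what a longer chain on the amide nitrogen would do.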